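Methyl in Place of Hydrogen on a Methylamino Chain

This account rests on a few compounds, and the source may have more. Where it says the series, first, only, none or still open, it means among the compounds named here.

Compound 1, `Cc1nnc(-c2nsc3ccccc23)o1`: 21%
Compound 2, `CCc1nnc(-c2nsc3ccccc23)o1`: 18%
Compound 3, `CNc1nnc(-c2nsc3ccccc23)o1`: 10%

In a functional assay on the whole organism for inhibition, with Rattus norvegicus as the target, with a stated time of 3.5 h, at a dose of 100 mg/kg by the oral route (on this read-out higher numbers stand for more inhibition at the one dose given (going by the name of the read-out) and lower numbers for less inhibition), compound 1 gives 21%, compound 2 gives 18% and compound 3 gives 10%. The three share one core, and the change from compound 1 to compound 2 is methyl in place of hydrogen on a saturated chain carbon bound to an aromatic carbon; this step is a number 3 percentage points lower from compound 1 to compound 2 (within the scatter). The two cores of compound 1 and compound 3 differ by methylamino in place of methyl on an aromatic carbon, and that step is a number 11 percentage points lower from compound 1 to compound 3 (beyond the scatter). Between compound 2 and compound 3 the step is a number 8 percentage points lower from compound 2 to compound 3 (within the scatter).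

Compound 4, `CCNc1nnc(-c2nsc3ccccc23)o1`, has not been measured in this assay. It differs from compound 3 by methyl in place of hydrogen on a saturated chain carbon bound to a nitrogen on an aromatic ring. This is the same kind of change as from compound 1 to compound 2, though not the same: there the place was on a saturated chain carbon bound to an aromatic carbon, here it is on a saturated chain carbon bound to a nitrogen on an aromatic ring. Because a number 3 percentage points lower from compound 1 to compound 2 (within the scatter) stayed within the scatter, the expected step is estimated as a number 2 percentage points lower from compound 3 to compound 4 (within the scatter). Compound 4 is therefore expected to give about 8%, between 0% and 20%.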

Compound 4, a percentage reported as inhibition, in the whole organism at one dose (the size of the read-out at that dose, not a potency): 29%
Beside the measured number, compound 4's estimate is 21 percentage points below it, outside the stated range (above it).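

In this assay, methyl in place of hydrogen did not carry over from one core to the other, since the step on the core with the methylamino group is a number 19 percentage points higher from compound 3 to compound 4 (beyond the scatter), and the two cases disagree: the same change on two cores in this assay, a number 3 percentage points lower (within the scatter) from compound 1 to compound 2 and a number 19 percentage points higher (beyond the scatter) from compound 3 to compound 4, 22 percentage points apart, beyond the scatter of two such steps

Within the data shown here, the other two steps place compound 4 among the earlier compounds: ethylamino in place of ethyl gives a number 11 percentage points higher from compound 2 to compound 4 (beyond the scatter), while ethylamino in place of methyl gives a number 8 percentage points higher from compound 1 to compound 4 (within the scatter). This single pair of steps, read at one dose, shows that the effect of this change cannot be assumed to transfer within this series, but it gives no general rule for other cores and no reason for the difference.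

As far as these compounds go, what propylamino or isopropylamino would give in place of ethylamino remains open, so it cannot be said whether the number keeps rising as the chain grows. The effect of dimethylamino on the shared core is also left open.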